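This account rests on a few compounds, and the source may have more. Where it says the series, first, only, none or still open, it means among the compounds named here.

In a functional assay on MCF7 cells (Homo sapiens) for cytotoxicity, read by MTT assay, with a stated time of 96 h (a higher number here means a weaker inhibitor, a lower number a stronger inhibitor), compound 1 `COc1cc(C(=O)c2cn(-c3ccccc3)cc2-c2ccc(Cl)cc2)cc(OC)c1OC` gives 290 nM, compound 2 `COc1cc(C(=O)c2cn(-c3ccccc3)cc2-c2ccccc2Br)cc(OC)c1OC` gives 190 nM, and compound 3 `COc1cc(C(=O)c2cn(-c3ccccc3)cc2-c2ccc([N+](=O)[O-])cc2)cc(OC)c1OC` gives 590 nM, the highest number of the three. Compound 4 `COc1cc(C(=O)c2cn(-c3cccc(C)c3)cc2-c2ccc([N+](=O)[O-])cc2)cc(OC)c1OC` departs from compound 3 by methyl in place of hydrogen on an aromatic carbon, turning phenyl into 3-methylphenyl. The measured steps are a 1.5-fold lower number from compound 1 to compound 2 (0.18 log units; within the scatter), a 2.0-fold higher number from compound 1 to compound 3 (0.31 log units; beyond the scatter) and a 3.1-fold higher number from compound 2 to compound 3 (0.49 log units; beyond the scatter). All three alter a different substituent of the shared core, so none tests this change directly, and they show only how far numbers have moved in this small set. The expected result is a 1.2-fold lower number from compound 3 to compound 4 (0.07 log units; within the scatter), with no step beyond the scatter and no firm direction anticipated. For compound 4 the estimated value is 500 nM, with an expected range from 220 nM to 1200 nM.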

Compound 4, half-maximal inhibitory concentration: 780 nM
The estimate for compound 4 lay 1.6-fold (0.19 log units) below the measured number, and the stated range covers the measured number.
By their numbers in this assay, from the lowest: compounds 2 and 1 (each within the scatter of the next); then compounds 3 and 4 (each within the scatter of the next).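

In this assay the change from phenyl to 3-methylphenyl gives a 1.3-fold higher number from compound 3 to compound 4 (0.12 log units; within the scatter) and so stays within the scatter. Among these compounds, this is the first direct reading of this ring, as the earlier steps all altered a different substituent, and here a methyl meta to a large group leaves the number essentially unmoved. Nothing available explains this result. The compounds shown leave open whether the methyl behaves alike with 4-chlorophenyl or 2-bromophenyl in place of 4-nitrophenyl. They also leave open whether a methoxy, an amine or a carboxylic acid at this place would move the number beyond the scatter.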